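Trimming a methyl from a methoxy-bearing side group

The compounds below may be only part of what the source reports. "The series", "measured", "known", "first", "only" and "open" are said of these compounds alone.

Measured compounds:
compound 1, `C[C@H](NC(=O)c1cc(C(F)(F)F)nn1C)c1nc(-c2cccnc2)no1`, 11800 nM
compound 2, `COC(C)(C)c1cc(-c2noc([C@H](C)NC(=O)c3cc(C(F)(F)F)nn3C)n2)ccn1`, 6280 nM

Both were tested in an assay on T-REx-293 cells for inhibition of potassium channel subfamily T member 1 (Homo sapiens), read by patch clamp; a higher number here means a weaker inhibitor, a lower number a stronger inhibitor. Compound 1 gives 11800 nM there, and compound 2 gives 6280 nM. Compound 2 has the lowest of the two numbers, but the gap to compound 1 lies within the scatter, so the two cannot be told apart.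

Compound 3, `CO[C@@H](C)c1cc(-c2noc([C@H](C)NC(=O)c3cc(C(F)(F)F)nn3C)n2)ccn1`, has not been measured. It differs from compound 2 in one place: 1-methoxyethyl in place of 1-methoxy-1-methylethyl on an aromatic carbon. The methoxy group stays; one methyl is taken away from the carbon that carries it, which creates a defined stereocentre.

Among the measured compounds shown here, no measured pair shows what such a change does here. The expectation for compound 3 in this assay is a step from compound 2 of about a 1.1-fold higher number from compound 2 to compound 3 (0.05 log units; within the scatter), that is, none beyond the scatter. Compound 3 is therefore estimated at 7000 nM, with a range from 2500 nM to 20000 nM.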

Compound 3, half-maximal inhibitory concentration: 744 nM
Beside the measured number, compound 3's estimate is 9.4-fold (0.97 log units) above it, outside the stated range (below it).
By their numbers in this assay, from the lowest: compound 3; then compounds 2 and 1 (each within the scatter of the next).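

Compound 1 and compound 2 could not be told apart, so they gave no sign that this side group mattered, yet in this assay trimming a single methyl from the carbon carrying the methoxy group gives an 8.4-fold lower number from compound 2 to compound 3 (0.93 log units; beyond the scatter). The larger ring-bearing group of compound 3 also stands well clear of the smaller one in compound 1, with a 16-fold lower number from compound 1 to compound 3 (1.20 log units; beyond the scatter), so the detail of the carbon next to the methoxy oxygen counts heavily at this position. No evidence here says why the number drops so far.

Compound 3 shows only one arrangement at its new stereocentre. The data do not separate that arrangement from the lost methyl. From the compounds shown here alone, whether the methoxy group itself is needed also stays open, a question that a hydroxyl or a plain ethyl at this place would address.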